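A few compounds are considered here, and "the series" means these few. Any claim that something is new, unique, unknown or untested is made for them only; others in the source may bear on it.

Compound 3 `COCCOc1nc(N)nc2c1ncn2/C=C1/CC1(CO)CO` has been tested in an ADME assay on CCRF-HSB-2 cells (Homo sapiens) for cytotoxicity, with a stated time of 7 days; a higher number here means that more compound is tolerated, a lower number that less compound is tolerated. For compound 3 the assay reports only a limit, > 20000 nM, and not a number. Two related compounds carry a sulfur-linked chain instead: compound 1 `CCCCSc1nc(N)nc2c1ncn2/C=C1/CC1(CO)CO` gives 89000 nM, and compound 2 `CC(C)CSc1nc(N)nc2c1ncn2/C=C1/CC1(CO)CO` gives 60000 nM. Compound 4 `CC(C)Sc1nc(N)nc2c1ncn2/C=C1/CC1(CO)CO` has not yet been measured. Its change from compound 3 is isopropylsulfanyl in place of 2-methoxyethoxy on an aromatic carbon. Among the compounds with values here, the steps that bear on this change are a step that the limit leaves unreadable from compound 1 to compound 3 and a step that the limit leaves unreadable from compound 2 to compound 3, both hidden by the limit, and a 1.5-fold lower number from compound 1 to compound 2 (0.17 log units; within the scatter), which lies within the scatter. Compound 4 is therefore expected to sit near compound 1 and compound 2. The expected step is a step that the limit leaves unreadable from compound 3 to compound 4. Compound 4 is estimated at 70000 nM, between 25000 nM and 200000 nM.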

Compound 4, half-maximal cytotoxic concentration: 94000 nM
Estimate against measurement, compound 4: 1.3-fold (0.13 log units) below; low and high end bracket the measured number.
By their numbers in this assay, from the lowest: compounds 2, 1 and 4 (each within the scatter of the next).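

In this assay, isopropyl on the sulfur behaves like isobutyl and butyl, with a 1.6-fold higher number from compound 2 to compound 4 (0.19 log units; within the scatter) and a 1.1-fold higher number from compound 1 to compound 4 (0.02 log units; within the scatter). Across these three sulfur-linked chains, the choice of chain therefore makes no readable difference. The steps involving compound 3 cannot be read, and so the effect of placing isopropylsulfanyl where 2-methoxyethoxy stood stays unknown, because compound 3 has only a limit: the limit of > 20000 nM in this assay, at which 1 of the 4 values shown sits.

The compounds shown leave open whether an amine or a carboxylic acid on this aromatic carbon would give numbers in the same range. They also leave open how a butoxy chain, joined through oxygen, would compare with the butyl chain on sulfur.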